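Nitrooxy and oxime chalcone anilides in rat paw edema

The source may report more compounds than this note shows. Statements on the series, on what has been measured and on what is new or still open speak of the compounds shown alone.

Measured so far:
compound 1, `O=C(CO[N+](=O)[O-])Nc1ccc(C(=O)/C=C/c2ccco2)cc1`, 39%
compound 2, `C/C(=N/O)c1ccc(OCC(=O)Nc2ccc(C(=O)/C=C/c3ccc(Cl)cc3)cc2)cc1`, 49%

Both compounds were tested in a functional assay on the whole organism (strain albino) for inhibition, with Rattus norvegicus as the target, read by paw edema, with stated times of 30 min and 5 h, at a dose of 100 mg/kg by the oral route; on this read-out higher numbers stand for more inhibition at the one dose given (going by the name of the read-out) and lower numbers for less inhibition. Compound 1 gives 39%, and compound 2 gives 49%. Compound 2 and compound 1 cannot be told apart in this assay, the gap between them lying within the usual scatter, so neither stands out on the two numbers at hand.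

Compound 3, `C/C(=N/O)c1ccc(OCC(=O)Nc2ccc(C(=O)/C=C/c3ccco3)cc2)cc1`, has not been measured. It differs from compound 2 in one place: furan-2-yl in place of 4-chlorophenyl on a double-bonded chain carbon bound to a double-bonded chain carbon. Going by the values given here, compound 1 already carries the furan-2-yl group on a different amide side chain, so the two measured compounds give no clean step for this change on its own.

The step from compound 2 to compound 3 in this assay is expected to be small, at most a slight fall, within the scatter: a number 6 percentage points lower from compound 2 to compound 3 (within the scatter). Compound 3 is therefore estimated at 43%, in the range 28% to 58%.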

Compound 3, a percentage reported as inhibition, in the whole organism at one dose (the size of the read-out at that dose, not a potency): 42%
Estimate against measurement, compound 3: 1 percentage points above; the measured number falls inside the stated range.
By their numbers in this assay, from the lowest: compounds 1, 3 and 2 (each within the scatter of the next).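

In this assay, furan-2-yl in place of 4-chlorophenyl on a double-bonded chain carbon bound to a double-bonded chain carbon gives a number 7 percentage points lower from compound 2 to compound 3 (within the scatter), so with the oxime side chain held constant, this change at this position cannot be told from scatter. With furan-2-yl held constant, the group of 10 heavy atoms carrying the oxime, in place of the group of 3 heavy atoms on an oxygen on a saturated carbon, gives a number 3 percentage points higher from compound 1 to compound 3 (within the scatter), and this exchange likewise cannot be told from scatter. No supporting measurement bears on either step.

As far as these compounds go, it remains open whether any other group at the first position, such as thiophen-2-yl or an aminophenyl, would give a step beyond the scatter. From the compounds shown here alone, it is also open whether a carboxylic acid in place of the oxime would do so.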